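Oxazolidinone side chains and cytotoxicity in a cell assay

A few compounds are considered here, and "the series" means these few. Any claim that something is new, unique, unknown or untested is made for them only; others in the source may bear on it.

Measured compounds:
compound 1, `CN(CCC#N)C[C@H]1CN(c2ccc(-n3cc(-c4ccccn4)cn3)c(F)c2)C(=O)O1`: > 400 ug/mL
compound 2, `O=C1O[C@@H](Cn2ccnn2)CN1c1ccc(-n2cc(-c3ccccn3)cn2)c(F)c1`: 225 ug/mL

Of the compounds shown here, two have been tested in an ADME assay on HEK293-A cells (Homo sapiens) for cytotoxicity, read by MTT assay, with a stated time of 48 h; on this read-out lower numbers stand for stronger inhibition and higher numbers for weaker inhibition. Compound 1 gives > 400 ug/mL, which is a limit of the assay and not a number. Among the measured compounds shown here, compound 2 gives 225 ug/mL in this assay, the only number among the two values, with the other value sitting at the limit of > 400 ug/mL in this assay, at which 1 of the 2 values shown sits. For the measured compounds named here, the one measured step, an at least 1.7-fold lower number from compound 1 to compound 2 (0.24 log units; that floor lies within the scatter), therefore has only a floor, and that floor lies within the scatter.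

Compound 3, `CNC(=O)[C@H]1CN(c2ccc(-n3cc(-c4ccccn4)cn3)c(F)c2)C(=O)O1`, has not yet been measured. It differs from compound 2 in one place: methylcarbamoyl in place of (1H-1,2,3-triazol-1-yl)methyl on a saturated ring carbon. No measured step changes this position, so the one step shown bears on compound 3 only in that both measured compounds sit at the weak end of this assay. The account expects compound 3 to stay in that weak region, with a 1.2-fold higher number from compound 2 to compound 3 (0.09 log units; within the scatter) and no step beyond the scatter; a further limit is also plausible. The estimate for compound 3 is 280 ug/mL, between 130 ug/mL and 400 ug/mL.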

Compound 3, half-maximal inhibitory concentration: 342 ug/mL
For compound 3 the middle estimate is 1.2-fold (0.09 log units) below the measured one, and the stated range covers the measured number.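

In this assay, replacing (1H-1,2,3-triazol-1-yl)methyl with methylcarbamoyl on this saturated ring carbon, next to the ring oxygen, gives a 1.5-fold higher number from compound 2 to compound 3 (0.18 log units; within the scatter). The position therefore takes a smaller group with no ring and with a hydrogen-bond donor, in place of a five-membered aromatic ring with no donor, without a difference that can be told from the scatter, and the two compounds cannot be placed in any order. The other new step, an at least 1.1-fold lower number from compound 1 to compound 3 (0.06 log units; that floor lies within the scatter), starts from a limit and not a number, so it cannot be read as a size: the limit of > 400 ug/mL in this assay, at which 1 of the 3 values shown sits.

The compounds shown leave open whether any group on this ring carbon can move the number beyond the scatter, since the only two numbers here lie within it. A free carboxylic acid, a primary amine or a longer chain carrying the amide might answer that, and a tertiary amide would show whether the amide hydrogen matters at all in this assay.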